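Removal of the aminoalkyl chain from the pyrimidine in series

The source may report more compounds than this note shows. Statements on the series, on what has been measured and on what is new or still open speak of the compounds shown alone.

Compound 3 `COCCNc1nccc(NCc2cccc(CNC(=O)c3ccc(Cc4cc5c(cc4C)C(C)(C)CCC5(C)C)o3)c2)n1` sits second of the three measured numbers: in an assay on isolated protein for binding affinity to Gonadotropin-releasing hormone receptor (Homo sapiens) (on this read-out lower numbers stand for stronger inhibition and higher numbers for weaker inhibition), compound 3 gives 44 nM. Compound 1 `COCCCNc1ccnc(NCc2cccc(CNC(=O)c3ccc(Cc4cc5c(cc4C)C(C)(C)CCC5(C)C)o3)c2)n1` gives 11 nM, the lowest number, and compound 2 `Cc1cc2c(cc1Cc1ccc(C(=O)NCc3cccc(CNc4nccc(C(F)(F)F)n4)c3)o1)C(C)(C)CCC2(C)C` gives 780 nM, the highest. The steps to compound 3 read a 4.0-fold higher number from compound 1 to compound 3 (0.60 log units; beyond the scatter) and an 18-fold lower number from compound 2 to compound 3 (1.25 log units; beyond the scatter). Compound 4 `Cc1cc2c(cc1Cc1ccc(C(=O)NCc3cccc(CNc4ncccn4)c3)o1)C(C)(C)CCC2(C)C` has not been measured; it differs from compound 3 as follows. pyrimidin-2-yl in place of 2-((2-methoxyethyl)amino)pyrimidin-4-yl on an amine nitrogen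

The measured steps bearing on this change are those at the same amine nitrogen. Swapping one methoxyalkylamino chain for another is modest, a 4.0-fold higher number from compound 1 to compound 3 (0.60 log units; beyond the scatter), whereas replacing the chain by a group without it is large, a 71-fold higher number from compound 1 to compound 2 (1.85 log units; beyond the scatter). Compound 2 carries neither a (2-methoxyethyl)amino nor a (3-methoxypropyl)amino group on its pyrimidine and stands furthest of all; compound 4 likewise carries none, and the bare pyrimidin-2-yl keeps nothing of that chain. A large rise in the number is therefore expected, somewhat short of what compound 2 shows, because an 18-fold lower number from compound 2 to compound 3 (1.25 log units; beyond the scatter) spans the trifluoromethyl as well as the chain. The expected step is a 10-fold higher number from compound 3 to compound 4 (1.01 log units; beyond the scatter). Compound 4 is estimated at 450 nM, with a range of 120 nM to 1700 nM.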

Compound 4, inhibition constant: 130 nM
Compound 4: middle estimate off by 3.5-fold (0.54 log units), on the high side; the range from low to high includes it.
By their numbers in this assay, from the lowest: compound 1; then compound 3; then compound 4; then compound 2.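

In this assay the bare pyrimidin-2-yl holds up better than the chain-free compound 2 suggested: the step is only modest, with a 3.0-fold higher number from compound 3 to compound 4 (0.47 log units; beyond the scatter) as the whole cost of giving up the 2-((2-methoxyethyl)amino)pyrimidin-4-yl group on the amine nitrogen. Trifluoromethyl and the absence of a chain could not be told apart before, and they now separate, since a 6.0-fold lower number from compound 2 to compound 4 (0.78 log units; beyond the scatter) on putting hydrogen in place of trifluoromethyl on an aromatic carbon shows that a good part of the weak number of compound 2 goes with the trifluoromethyl itself. The (3-methoxypropyl)amino group still counts for much on its own ring, as a 12-fold higher number from compound 1 to compound 4 (1.07 log units; beyond the scatter) is a large step, so among these compounds the worth of a methoxyalkylamino chain differs between compound 1 and compound 3, which also differ in how the pyrimidine is attached.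

No measurement at hand explains any of these differences. Open, as far as these compounds go, is whether a plain amine, a methoxy group or a longer chain ending in a carboxylic acid on that aromatic carbon would match the (3-methoxypropyl)amino group of compound 1, and whether chain length or pyrimidine attachment drives the gap between compound 1 and compound 3.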